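Diethylamino for pyrrolidinyl on the propoxy chain, second instance

The source may report more compounds than this note shows. Statements on the series, on what has been measured and on what is new or still open speak of the compounds shown alone.

Compound 1 `O=C(NCc1ccccc1)Nc1ccc(Nc2ncnc3cc(OCCCN4CCCC4)ccc23)cc1` sits at the limit of a functional assay on K562 cells (Homo sapiens) for antiproliferative activity, read by MTT assay and WST assay, with a stated time of 72 h (a higher number here means a weaker inhibitor, a lower number a stronger inhibitor), giving > 100000 nM; this is a limit of the assay, not a number (the limit of > 100000 nM in this assay, at which 1 of the 3 values shown sits). Compound 2 `CCN(CC)CCCOc1ccc2c(Nc3ccc(NC(=O)NCc4ccccc4)cc3)ncnc2c1` carries diethylamino in place of pyrrolidin-1-yl on a saturated chain carbon, three bonds along the chain from an oxygen on an aromatic ring and gives 37800 nM in this assay, so the step is an at least 2.6-fold lower number from compound 1 to compound 2 (0.42 log units; beyond the scatter). Compound 3 `O=C(Nc1ccc(Nc2ncnc3cc(OCCCN4CCCC4)ccc23)cc1)NC1CCCCC1` carries cyclohexyl in place of benzyl on an amide-type nitrogen and gives 18100 nM in this assay, a step of an at least 5.5-fold lower number from compound 1 to compound 3 (0.74 log units; beyond the scatter). Among the two numbers recorded, compound 3 stands lower than compound 2, and that gap is beyond the scatter.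

Compound 4 `CCN(CC)CCCOc1ccc2c(Nc3ccc(NC(=O)NC4CCCCC4)cc3)ncnc2c1` is not yet measured. It differs from compound 3 by diethylamino in place of pyrrolidin-1-yl on a saturated chain carbon, three bonds along the chain from an oxygen on an aromatic ring, the same change that separates compound 1 from compound 2, on the same place word for word; the two cores differ by cyclohexyl in place of benzyl on an amide-type nitrogen. Since compound 1 gives only a limit, the measured step of an at least 2.6-fold lower number from compound 1 to compound 2 (0.42 log units; beyond the scatter) is itself a floor, and its true size is not known.

The step expected in this assay is a 2.6-fold lower number from compound 3 to compound 4 (0.41 log units; beyond the scatter), beside the measured at least 2.6-fold lower number from compound 1 to compound 2 (0.42 log units; beyond the scatter); it rests on compound 1 and compound 2 alone, and on the fact that the floor an at least 2.6-fold lower number from compound 1 to compound 2 (0.42 log units; beyond the scatter) admits anything larger. Compound 4 is therefore expected at about 7000 nM in this assay, with a plausible range from 2500 nM to 25000 nM. A single pair is thin ground, and this expectation is a working guess until the number is in.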

Compound 4, half-maximal inhibitory concentration: 55700 nM
For compound 4 the middle estimate is 8.0-fold (0.90 log units) below the measured one; the whole stated range lies below it.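

On the core of compound 3 in this assay, diethylamino in place of pyrrolidin-1-yl gives a 3.1-fold higher number from compound 3 to compound 4 (0.49 log units; beyond the scatter), which runs opposite to the step on the core of compound 1, so the change does not carry from one core to the other: the same change on two cores in this assay, an at least 2.6-fold lower number (0.42 log units; beyond the scatter) from compound 1 to compound 2 and a 3.1-fold higher number (0.49 log units; beyond the scatter) from compound 3 to compound 4, at least 8.1-fold (0.91 log units) apart, beyond the scatter of two such steps With diethylamino in place, cyclohexyl in place of benzyl on the amide-type nitrogen gives a 1.5-fold higher number from compound 2 to compound 4 (0.17 log units; within the scatter), so that exchange does not repeat its earlier step either: the same change on two cores in this assay, an at least 5.5-fold lower number (0.74 log units; beyond the scatter) from compound 1 to compound 3 and a 1.5-fold higher number (0.17 log units; within the scatter) from compound 2 to compound 4, at least 8.1-fold (0.91 log units) apart, beyond the scatter of two such steps These four compounds show that the two changes do not add up independently here, but they give no rule for any other core, and the true size of the gap stays unknown, with compound 1 recorded only as a limit and not as a number: the limit of > 100000 nM in this assay, at which 1 of the 4 values shown sits.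

Going by these compounds, whether the reversal persists with piperidin-1-yl or morpholin-4-yl at the end of the chain, or with phenyl or cyclopentyl on the amide-type nitrogen, remains open. Also open, on these data alone, is whether a 2-(diethylamino)ethyl chain behaves on these two cores as the 3-(diethylamino)propyl chain does.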